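The source may hold more compounds than are shown below. What is called first, only, known or untested is meant among the compounds shown, and "the series" means these compounds.

Of the compounds shown here, three have been measured so far. Compound 1 `N#Cc1ccc(-c2nnc(-c3ccc(S(N)(=O)=O)cc3)o2)cc1`, compound 2 `N#Cc1ccc(C(=O)NNC(=O)c2ccc(S(N)(=O)=O)cc2)cc1` and compound 3 `NS(=O)(=O)c1ccc(-c2nnc(-c3ccc(Cl)c(Cl)c3)o2)cc1` share a common core and differ at its far end. In an assay on cells for inhibition of Amine oxidase [flavin-containing] A (Homo sapiens), read by fluorescence and spectrophotometry, using microsomes, with a stated time of 20 min (on this read-out lower numbers stand for stronger inhibition and higher numbers for weaker inhibition), compound 1 gives 24300 nM. In this assay compound 2 gives 16100 nM. In this assay compound 3 gives 46200 nM, the highest number of the three: its gap to compound 1 lies within the usual scatter, while its gap to compound 2 lies beyond it, so only compound 2 stands clearly apart from compound 3.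

Compound 4 `NS(=O)(=O)c1ccc(-c2nnc(-c3ccc(Cl)cc3)o2)cc1` has not yet been measured. It differs from compound 3 in a single place: hydrogen in place of chloro on an aromatic carbon. The chlorine is removed from an aromatic carbon of a six-membered aromatic ring of carbon only, ortho to a chloro group and meta to a large group. Within the data shown here, no two measured compounds in this set differ in one place, so there is no measured step to lean on. The step of a 1.0-fold lower number from compound 3 to compound 4 (0.01 log units; within the scatter) is expected to stay within the scatter, with no firm direction, if anything a slight drift toward a higher number. For compound 4 the estimate in this assay is 45000 nM, with a range from 18000 nM to 110000 nM.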

Compound 4, half-maximal inhibitory concentration: 68000 nM
Compound 4: the middle estimate sits 1.5-fold (0.18 log units) below what was measured; the measured number falls inside the stated range.
By their numbers in this assay, from the lowest: compounds 2, 1, 3 and 4 (each within the scatter of the next, the first and the last beyond it).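

In this assay, among these compounds, hydrogen in place of chloro on an aromatic carbon, ortho to a chloro group and meta to a large group, gives the first measured one-place step at this position (a 1.5-fold higher number from compound 3 to compound 4 (0.17 log units; within the scatter)), so compound 3 and compound 4 cannot be told apart and the second chloro group makes no clear difference here. The exchange of chloro for cyano on an aromatic carbon, by contrast, gives a modest step beyond the scatter (a 2.8-fold higher number from compound 1 to compound 4 (0.45 log units; beyond the scatter)), which shows that the choice of group on that ring can register in this assay, with the nitrile-bearing compound 1 giving the lower number. Nothing at hand explains the size of either step.

The compounds shown leave open whether a group such as an amine, a methoxy group or a carboxylic acid at the position of the lost chloro group would give a step beyond the scatter. They also leave open what hydrogen in place of the remaining chloro group would do, and whether any group on this ring could bring the number close to that of compound 2.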